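The source may hold more compounds than are shown below. What is called first, only, known or untested is meant among the compounds shown, and "the series" means these compounds.

Compound 1 `O=[N+]([O-])c1cn2c(n1)OC[C@@H](OCc1ccc(-c3ccc(F)cc3)s1)C2`, compound 2 `COc1ccc(-c2ccc(CO[C@@H]3COc4nc([N+](=O)[O-])cn4C3)s2)cc1F`, compound 3 `O=[N+]([O-])c1cn2c(n1)OC[C@@H](OCc1cc(-c3ccc(F)cc3)no1)C2` and compound 4 `COc1ccc(-c2cc(CO[C@@H]3COc4nc([N+](=O)[O-])cn4C3)on2)cc1F` were examined for their effect on host cells in an ADME assay on Vero cells (Chlorocebus sabaeus) for cytotoxicity, with a stated time of 72 h; on this read-out lower numbers stand for stronger inhibition and higher numbers for weaker inhibition. In this assay compound 1 gives > 128000 nM, which is a limit of the assay and not a number. Compound 2 gives > 128000 nM in this assay, again a limit rather than a number. Compound 3 likewise gives > 128000 nM in this assay, a limit only. All three results sit at the same limit, as the limit of > 128000 nM in this assay, at which 3 of the 3 values shown sit, records, so none of them can be told apart from another.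

Compound 1 and compound 2 differ in one place: 3-fluoro-4-methoxyphenyl in place of 4-fluorophenyl on an aromatic carbon. The step they make in this assay is a step that the two limits leave unreadable from compound 1 to compound 2. Compound 3 and compound 4 differ by the same kind of change: 3-fluoro-4-methoxyphenyl in place of 4-fluorophenyl on an aromatic carbon. The surroundings of the place are not identical, since in compound 1 the group sits next to the ring sulfur of a five-membered aromatic ring with 1 sulfur, whereas in compound 3 it sits next to the ring nitrogen of a five-membered aromatic ring with 1 nitrogen and 1 oxygen, two ring bonds from the ring oxygen. How the core of compound 3 differs from the core of compound 1 is not broken down here.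

The step in this assay is expected to be a step that the limit leaves unreadable from compound 3 to compound 4, and this rests on a step that the two limits leave unreadable from compound 1 to compound 2 together with the limit of > 128000 nM in this assay, at which 3 of the 3 values shown sit. Compound 4 is accordingly expected to show 160000 nM in this assay, which would most likely appear once more only as a limit.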

Compound 4, half-maximal inhibitory concentration: > 128000 nM
Compound 4 gave a limit, no number; the forecaster's own chance of this, stated with the estimate: 85%; the middle value is on the limit's open side.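

No new step can be read from compound 3 to compound 4, because both results, like those of compound 1 and compound 2, are limits and not numbers: the limit of > 128000 nM in this assay, at which 4 of the 4 values shown sit.

The compounds shown leave open how far beyond this limit each one lies in this assay, and whether 3-fluoro-4-methoxyphenyl in place of 4-fluorophenyl changes the read-out at all.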